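Methoxy for Methyl on the Aniline Ring

The source may hold more compounds than are shown below. What is called first, only, known or untested is meant among the compounds shown, and "the series" means these compounds.

Of the compounds shown here, three that share one core have been tested in an assay on isolated protein for inhibition of phosphatidylinositol 4,5-bisphosphate 3-kinase catalytic subunit beta isoform (Homo sapiens); on this read-out higher numbers stand for weaker inhibition and lower numbers for stronger inhibition. Compound 1 `Clc1ccc(Nc2nccc(-c3ccc(Cl)cc3Cl)n2)c(Cl)c1` gives 799 nM in this assay. Compound 2 `Clc1ccc(Nc2nccc(-c3ccc(Cl)c(Cl)c3)n2)c(Cl)c1` gives 926 nM. Compound 3 `Cc1cccc(Nc2nccc(-c3ccc(Cl)cc3Cl)n2)c1` gives 851 nM, the second highest of the three numbers; its gaps to compound 1 and to compound 2 both fall within the usual scatter of repeated measurements, so the three compounds cannot be ordered against one another on this read-out.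

Compound 4 `COc1cccc(Nc2nccc(-c3ccc(Cl)cc3Cl)n2)c1` has not yet been measured in this assay. It differs from compound 3 in one place: methoxy in place of methyl on an aromatic carbon. Among the compounds with values here, no measured pair in this set shows the same exchange, so there is no direct precedent for the size or direction of the step. The three measured compounds sit close together despite differing in chlorine or methyl substitution on either outer ring, which suggests that small changes on the periphery have so far moved the numbers little.

On that basis the change is expected to bring a step of a 1.1-fold lower number from compound 3 to compound 4 (0.03 log units; within the scatter), no larger than the scatter. For compound 4 the estimated value in this assay is 800 nM, with a range from 300 nM to 2500 nM.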

Compound 4, half-maximal inhibitory concentration: 893 nM
Compound 4: middle estimate off by 1.1-fold (0.05 log units), on the low side, within the range that was stated.
By their numbers in this assay, from the lowest: compounds 1, 3, 4 and 2 (each within the scatter of the next).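

In this assay the exchange of methyl for methoxy on an aromatic carbon, meta to a large group, brings a step of a 1.0-fold higher number from compound 3 to compound 4 (0.02 log units; within the scatter) and gives this set its first direct reading of that change. The exchange adds one heavy atom, an oxygen, and one hydrogen-bond acceptor, yet the read-out does not tell the two compounds apart, so at this position the added atom and acceptor bring no difference that can be separated from repeat measurements. Nothing measured here explains why the two groups read alike.

Still open, on these data alone, is whether a clearly different group at this same place, such as an amine, a carboxylic acid or a longer chain, would move the number beyond the scatter. Also open, as far as these compounds go, is whether methoxy in place of methyl would read the same way at another place on this ring, as this single pair speaks for one position only.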